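Fluorine Added to the Benzyl Group of Compound 3

The source may report more compounds than this note shows. Statements on the series, on what has been measured and on what is new or still open speak of the compounds shown alone.

Three compounds on one shared core have been examined in an ADME assay on MT4 cells (Homo sapiens) for cytotoxicity, read by MTT assay, with a stated time of 5 days; a lower number here means that less compound is tolerated, a higher number that more compound is tolerated. Compound 1 `N#Cc1ccccc1CN1C(=O)N(Cc2cccc(F)c2)S(=O)(=O)n2cccc21` reaches only the limit of the assay, > 305000 nM, which is a bound and not a number. Compound 2 `O=C1N(Cc2ccccc2Cl)c2cccn2S(=O)(=O)N1Cc1cccc(F)c1` gives 231000 nM. Among the measured compounds shown here, the only step measured between two compounds that differ in one place is an at least 1.3-fold lower number from compound 1 to compound 2 (0.12 log units; that floor lies within the scatter). Compound 3 `O=C1N(Cc2ccccc2Br)c2cccn2S(=O)(=O)N1Cc1ccccc1` gives 226000 nM, the lowest of the two numbers, with compound 2 as its nearest neighbour within the scatter. Compound 4 `O=C1N(Cc2ccccc2Br)c2cccn2S(=O)(=O)N1Cc1cccc(F)c1` differs from compound 3 by fluoro in place of hydrogen on an aromatic carbon. For the measured compounds named here, no measured step covers this change; compound 2 and compound 3 differ in two places at once and their values lie close together. Compound 4 is therefore expected to show no step beyond the scatter, a 1.0-fold lower number from compound 3 to compound 4 (0.01 log units; within the scatter). Compound 4 is estimated at 220000 nM, between 110000 nM and 400000 nM.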

Compound 4, half-maximal cytotoxic concentration: > 269000 nM
Compound 4: a limit, no number; the forecaster's own chance of this, stated with the estimate: 25%; middle value at least 1.2-fold (0.08 log units) away from the limit.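

Compound 4 in this assay returns a limit of the assay and not a number: the limit of > 269000 nM in this assay, at which 1 of the 4 values shown sits.

Fluoro in place of hydrogen gives an at least 1.1-fold higher number from compound 3 to compound 4 (0.07 log units; that floor lies within the scatter), and bromo in place of chloro gives an at least 1.1-fold higher number from compound 2 to compound 4 (0.06 log units; that floor lies within the scatter), so neither floor shows a step beyond the scatter. The step between compound 1 and compound 4 joins two limits and cannot be read.

The compounds shown leave open how far the true value of compound 4 lies past its limit. They also leave open whether an amine or a carboxylic acid on the benzyl group would shift the tolerated concentration.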